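This account rests on a few compounds, and the source may have more. Where it says the series, first, only, none or still open, it means among the compounds named here.

Compound 2, `NC(=O)C(O)CCO`, is a short chain carrying an amide at one end, a hydroxy at the other end and a second hydroxy on the chain itself. In an assay for inhibition of alcohol dehydrogenase (Equus caballus) (a lower number here means a stronger inhibitor, a higher number a weaker inhibitor), compound 2 gives 5800000 nM, the highest number among the three compounds measured here, so it is the weakest inhibitor of the set. Compound 3, `CC(C)CC[S+](C)[O-]`, a short branched sulfoxide, gives 430000 nM in this assay, a lower number than compound 2 by a margin beyond the scatter. Compound 1, `CCCCCCCCCCCCCC[S+](C)[O-]`, a sulfoxide on a long straight chain, gives 10000 nM in this assay, by far the lowest number shown.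

The step from compound 2 leads to compound 4, `NC(=O)CCCO`, with one change: hydrogen in place of hydroxy on a saturated chain carbon bound to a carbonyl carbon and a saturated chain carbon. For the measured compounds named here, no comparable step between two measured compounds is available to guide the expectation, so the size of the step is open. Given that compounds 1 and 3 show that a plain chain without hydroxy groups can inhibit more strongly, a modest drop in the number, roughly at the edge of the scatter, is expected, written as a 1.9-fold lower number from compound 2 to compound 4 (0.29 log units; within the scatter). Compound 4 is therefore estimated at 3000000 nM, in a range from 800000 nM to 12000000 nM.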

Compound 4, inhibition constant: 6800000 nM
The estimate for compound 4 lay 2.3-fold (0.36 log units) below the measured number, within the range that was stated.
By their numbers in this assay, from the lowest: compound 1; then compound 3; then compounds 2 and 4 (each within the scatter of the next).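

Replacing the hydroxy with hydrogen on a saturated chain carbon bound to a carbonyl carbon and a saturated chain carbon leaves the result in this assay essentially unchanged: a 1.2-fold higher number from compound 2 to compound 4 (0.07 log units; within the scatter). For this pair, then, the hydroxy at this place neither clearly strengthens nor clearly weakens inhibition, and its loss is not a route to a better inhibitor. Nothing available here explains why the change has so little effect.

Hydrogen and hydroxy are the only two groups compared at this place, so it remains open whether an amine or a methyl there would shift the number. On these data alone, it is also open whether replacing the amide with a carboxylic acid, or using a longer chain, would matter more than this change did.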